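The compounds below may be only part of what the source reports. "The series", "measured", "known", "first", "only" and "open" are said of these compounds alone.

Within the data shown here, compound 2 `O=C(O)CCc1ccc(S(=O)(=O)NNc2ccc(Br)cc2)cc1` gives 183 nM in an assay on HeLa cells for inhibition of Indoleamine 2,3-dioxygenase 1 (Homo sapiens), read by spectrophotometry, with a stated time of 24 h (a higher number here means that more compound is needed for the effect, a lower number that less compound is needed), the top of the two numbers measured so far, although the gap to its only neighbour lies within the scatter. Compound 1 `O=S(=O)(NNc1ccc(Br)cc1)c1ccccc1` gives 128 nM in this assay. Among the measured compounds shown here, the single measured step shows a 1.4-fold higher number from compound 1 to compound 2 (0.16 log units; within the scatter). Compound 3 `O=C(O)COc1ccc(S(=O)(=O)NNc2ccc(Br)cc2)cc1` differs from compound 2 by carboxymethoxy in place of 2-carboxyethyl on an aromatic carbon. For the measured compounds named here, no measured step bears directly on this swap; the one step available stayed within the scatter, so no shift beyond it is expected, and a 1.1-fold higher number from compound 2 to compound 3 (0.04 log units; within the scatter) is the expected step. Compound 3 is estimated at 200 nM, with a range from 100 nM to 400 nM.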

Compound 3, half-maximal effective concentration: 152 nM
Estimate against measurement, compound 3: 1.3-fold (0.12 log units) above, and the stated range covers the measured number.
By their numbers in this assay, from the lowest: compounds 1, 3 and 2 (each within the scatter of the next).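

In this assay the change from 2-carboxyethyl to carboxymethoxy, on an aromatic carbon para to a large group, brings a 1.2-fold lower number from compound 2 to compound 3 (0.08 log units; within the scatter) and so shows that this position accepts a second chain of the same heavy-atom count, with oxygen in place of one carbon. Set against plain hydrogen at this position, carboxymethoxy brings a 1.2-fold higher number from compound 1 to compound 3 (0.07 log units; within the scatter) and again moves the number no further than the scatter. From the compounds shown here alone, whether an amine or a longer chain at this position would behave the same stays open. No supporting evidence explains these results.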